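Bromo in Place of Hydrogen on Two Related Cores

A few compounds are considered here, and "the series" means these few. Any claim that something is new, unique, unknown or untested is made for them only; others in the source may bear on it.

Measured so far:
Compound 1, `CCCNC(=O)C1CCN(C(=O)c2cc3ccsc3n2Cc2ccc(OC)cc2)CC1`, gives 0.068 h in an ADME assay on microsomes from liver (Homo sapiens) for metabolic stability; on this read-out higher numbers stand for a longer-lived compound and lower numbers for a shorter-lived compound.
Compound 2, `CCCNC(=O)C1CCN(C(=O)c2cccn2Cc2ccc(OC)cc2)CC1`, gives 0.112 h in this assay.
Compound 3, `CCCNC(=O)C1CCN(C(=O)c2cc3cc(Br)sc3n2Cc2ccc(OC)cc2)CC1`, gives 0.127 h in this assay.

Compound 1 and compound 2 share the propylamide piperidine part and the 4-methoxybenzyl group but have different cores; how the two cores differ is not broken down here. Their values, together with that of compound 3, all lie within the scatter of one another.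

Compound 3 arises from compound 1 by bromo in place of hydrogen on an aromatic carbon, and this step gave a 1.9-fold higher number from compound 1 to compound 3 (0.27 log units; within the scatter). Compound 4, `CCCNC(=O)C1CCN(C(=O)c2cc(Br)cn2Cc2ccc(OC)cc2)CC1`, is not yet measured; it arises from compound 2 by bromo in place of hydrogen on an aromatic carbon. This is the same kind of change, not the same one: in compound 3 the bromo sits on a five-membered aromatic ring with one sulfur, part of a fused system of two rings, next to the ring sulfur, whereas in compound 4 it sits on a five-membered aromatic ring with one nitrogen, two ring bonds from the ring nitrogen.

Because the earlier step was a 1.9-fold higher number from compound 1 to compound 3 (0.27 log units; within the scatter), a step of similar size is expected for a 1.4-fold higher number from compound 2 to compound 4 (0.15 log units; within the scatter). Compound 4 is therefore estimated at 0.16 h in this assay, likely between 0.07 h and 0.35 h.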

Compound 4, half-life: 0.0362 h
Compound 4: middle estimate off by 4.4-fold (0.65 log units), on the high side, outside the stated range (below it).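

In this assay, bromo in place of hydrogen on an aromatic carbon gave a 3.1-fold lower number from compound 2 to compound 4 (0.49 log units; beyond the scatter), and this step cannot be predicted from the one seen on the core of compound 1, as the two steps differ clearly: the same change on two cores in this assay, a 1.9-fold higher number (0.27 log units; within the scatter) from compound 1 to compound 3 and a 3.1-fold lower number (0.49 log units; beyond the scatter) from compound 2 to compound 4, 5.8-fold (0.76 log units) apart, beyond the scatter of two such steps. So in this series, the effect of this change on one core is not a safe guide to its effect on another, even though both changes put a bromo on a five-membered aromatic ring. This does not show why the steps differ, since the bromo also sits in a different setting in each pair, and two pairs cannot separate the influence of the core from that of the position or say how any further core would behave.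

On these data alone, it remains open whether a chloro or a methyl group, two ring bonds from the ring nitrogen, would follow the step seen with bromo. As far as these compounds go, it also remains open whether a longer chain in place of the propyl group on the amide would alter the size of this step.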